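Dichloro Variant Under Cytotoxicity Test

The source may report more compounds than this note shows. Statements on the series, on what has been measured and on what is new or still open speak of the compounds shown alone.

Compound 1 `Cc1ccc(/C=C\C(=O)N2N=C(c3ccncc3)OC2c2c[nH]c3ccccc23)cc1`: > 30 ug/mL
Compound 2 `O=C(/C=C\c1ccc(Cl)cc1)N1N=C(c2ccncc2)OC1c1c[nH]c2ccccc12`: > 30 ug/mL

In an ADME assay on HeLa cells (Homo sapiens) for cytotoxicity, read by MTT assay, with a stated time of 72 h (a higher number here means a weaker inhibitor of growth, a lower number a stronger inhibitor of growth), compound 1 gives > 30 ug/mL, which is a limit of the assay and not a number. Compound 2 gives > 30 ug/mL in this assay, also a limit. Compound 2 thus stands at the top of the measured range, with nothing to separate it from compound 1, because both values sit at the limit of > 30 ug/mL in this assay, at which 2 of the 2 values shown sit. The step that the two limits leave unreadable from compound 1 to compound 2 cannot be read in size or direction.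

Compound 3 `O=C(/C=C\c1cccc(Cl)c1Cl)N1N=C(c2ccncc2)OC1c1c[nH]c2ccccc12` has not yet been measured. It differs from compound 2 by 2,3-dichlorophenyl in place of 4-chlorophenyl on a double-bonded chain carbon bound to a double-bonded chain carbon. Within the data shown here, no readable step bears on this change, and the single measured step gave no number. Compound 3 is therefore expected to give about 40 ug/mL in this assay. The range expected for compound 3 runs from 20 ug/mL to 100 ug/mL. The step that the limit leaves unreadable from compound 2 to compound 3 is expected to be none beyond the scatter, and most likely another limit.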

Compound 3, concentration for 50% growth inhibition: > 30 ug/mL
Compound 3 was reported as a limit; the forecaster's own chance of this, stated with the estimate: 85%; the middle value does not contradict the limit.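

In this assay compound 3 gives > 30 ug/mL, a limit of the assay and not a number. No new step can be read among compound 1, compound 2 and compound 3: the limit of > 30 ug/mL in this assay, at which 3 of the 3 values shown sit. The compounds shown leave open how these three compare, and whether 2,3-dichlorophenyl in place of 4-chlorophenyl changes growth inhibition at all.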